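A few compounds are considered here, and "the series" means these few. Any claim that something is new, unique, unknown or untested is made for them only; others in the source may bear on it.

Of the compounds shown here, three that share one core have been tested in a functional assay on OVCAR-8 cells (Homo sapiens) for inhibition, read by sulforhodamine B assay, with a stated time of 48 h, tested at 10 uM; on this read-out higher numbers stand for more inhibition at the one concentration tested (going by the name of the read-out) and lower numbers for less inhibition. Compound 1 `Brc1cn2ccnc2c(-c2ccc3ncn(C4CCCCC4)c3c2)n1` gives 4.92%, compound 2 `Fc1ccc(-c2cn3ccnc3c(-c3ccc4ncn(C5CCCCC5)c4c3)n2)cc1` gives 9.54%, and compound 3 `Clc1ccc(-c2cn3ccnc3c(-c3ccc4ncn(C5CCCCC5)c4c3)n2)cc1` gives 3.78%. Compound 3 has the smallest number of the three, but every gap is within the scatter: a number 1.1 percentage points lower from compound 1 to compound 3 (within the scatter) and a number 5.8 percentage points lower from compound 2 to compound 3 (within the scatter), so the numbers of the three in this assay cannot be set higher or lower than one another.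

Compound 4 `Fc1ccccc1-c1cn2ccnc2c(-c2ccc3ncn(C4CCCCC4)c3c2)n1` differs from compound 3 by 2-fluorophenyl in place of 4-chlorophenyl on an aromatic carbon. Among the compounds with values here, two measured steps bear on it. The exchange of one halogen for another on the attached phenyl gave a number 5.8 percentage points lower from compound 2 to compound 3 (within the scatter), and placing either halogenated phenyl in place of bromo gave a number 4.6 percentage points higher from compound 1 to compound 2 (within the scatter) and a number 1.1 percentage points lower from compound 1 to compound 3 (within the scatter). Within the data shown here, every one of these changes left the read-out flat, so no step beyond the scatter is expected for this assay; the move of the fluorine to another carbon of the phenyl has no measured precedent here, and the expectation is a number 2.2 percentage points higher from compound 3 to compound 4 (within the scatter). The estimate for compound 4 is 6%, with a range from -5% to 20%.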

Compound 4, a percentage reported as inhibition, at one concentration (the size of the read-out at that concentration, not a potency): 14.1%
Compound 4: middle estimate off by 8.1 percentage points, on the low side; the range from low to high includes it.
By their numbers in this assay, from the lowest: compounds 3, 1, 2 and 4 (each within the scatter of the next, the first and the last beyond it).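

Within the data shown here, this is the first step in this assay that lies beyond the scatter, a number 10.3 percentage points higher from compound 3 to compound 4 (beyond the scatter), though it is a modest one and the change from 4-chlorophenyl to 2-fluorophenyl alters both the halogen and where it sits on the phenyl. The two single comparisons around it stay within the scatter: exchanging 4-fluorophenyl for 2-fluorophenyl gives a number 4.6 percentage points higher from compound 2 to compound 4 (within the scatter), and exchanging bromo for 2-fluorophenyl gives a number 9.2 percentage points higher from compound 1 to compound 4 (within the scatter), so neither the halogen's location nor the added ring can be singled out as the source of the step. Nothing available explains this difference.

The compounds shown leave open which of the two alterations matters, and 2-chlorophenyl would separate them. They also leave open how a phenyl carrying an amine or a carboxylic acid would read at this place.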